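Does a Chloro Group Change Binding in This Amine Series?

The source may hold more compounds than are shown below. What is called first, only, known or untested is meant among the compounds shown, and "the series" means these compounds.

Compound 1, `c1ccc(Nc2ccc(N3CC4CC(C3)N4)nn2)cc1`, gives 441 nM in an assay on cell membranes for displacement of a labelled ligand from Neuronal acetylcholine receptor; alpha4/beta2 (Rattus norvegicus); a lower number here means a stronger inhibitor, a higher number a weaker inhibitor.
Compound 2, `COc1ccc(Nc2ccc(N3CC4CC(C3)N4)nn2)cc1`, gives 578 nM in this assay.
Compound 3, `CN(c1ccccc1)c1ccc(N2CC3CC(C2)N3)nn1`, gives 1430 nM in this assay.

Compound 1 has the lowest number of the three, but compound 2 sits so close that the two cannot be told apart: a 1.3-fold higher number from compound 1 to compound 2 (0.12 log units; within the scatter). Compound 3 does stand apart, as a modest step: a 3.2-fold higher number from compound 1 to compound 3 (0.51 log units; beyond the scatter).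

Compound 4, `Clc1cccc(Nc2ccc(N3CC4CC(C3)N4)nn2)c1`, is still to be measured. It differs from compound 1 in one place: chloro in place of hydrogen on an aromatic carbon. Within the data shown here, of the measured steps, only the one from compound 1 to compound 2 concerns the same six-membered ring of carbon only, there with methoxy in place of hydrogen on an aromatic carbon, and that step stayed within the scatter. The step from compound 1 to compound 3 concerns a different place, a nitrogen on an aromatic ring, so it offers little guidance for a change on the carbon ring.

With one relevant comparison showing no movement, compound 4 is expected to show no step beyond the scatter in this assay, in either direction. Compound 4 is therefore estimated at about 400 nM, between 150 nM and 1100 nM. That estimate corresponds to a 1.1-fold lower number from compound 1 to compound 4 (0.04 log units; within the scatter).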

Compound 4, inhibition constant: 1540 nM
For compound 4 the middle estimate is 3.9-fold (0.59 log units) below the measured one; the measured number lies above the stated range.
By their numbers in this assay, from the lowest: compounds 1 and 2 (each within the scatter of the next); then compounds 3 and 4 (each within the scatter of the next).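

The ring of compound 1 does respond to a small change: in this assay, one chlorine, a single heavy atom on an aromatic carbon meta to a large group, gives a modest loss of binding strength that goes beyond the usual scatter (a 3.5-fold higher number from compound 1 to compound 4 (0.54 log units; beyond the scatter)). The methoxy step on the same six-membered ring stayed within the scatter (a 1.3-fold higher number from compound 1 to compound 2 (0.12 log units; within the scatter)), so that step alone was no safe guide to every change on this ring, and a replacement of hydrogen here cannot be assumed to leave the number unchanged. No measurement shown here explains why the chloro step moved the number.

The compounds shown do not separate the effect of the chloro group itself from the effect of its place on the ring, since the comparison rests on only these two changes to that ring. A methyl group or a nitrile at the same place, or a chloro group on another carbon of the ring, would show which of the two matters.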